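This account rests on a few compounds, and the source may have more. Where it says the series, first, only, none or still open, it means among the compounds named here.

Measured in a functional assay on MCF7 cells (Homo sapiens) for antiproliferative activity, read by sulforhodamine B assay, with a stated time of 48 h; on this read-out lower numbers stand for stronger inhibition and higher numbers for weaker inhibition:
- compound 1 `CCc1ccccc1NS(=O)(=O)c1ccc(N2CCNC2=O)cc1`: 350 nM
- compound 2 `O=C1NCCN1c1ccc(S(=O)(=O)Nc2ccc(F)c(F)c2)cc1`: 620 nM
- compound 3 `CCc1cccc(NS(=O)(=O)c2ccc(N3CCNC3=O)cc2)c1`: 130 nM

Of these three, compound 3 has the lowest number, 130 nM, and its gaps to the other two lie beyond the scatter. Compound 4 `O=C1NCCN1c1ccc(S(=O)(=O)Nc2cccc(Br)c2)cc1` has not yet been measured. It keeps everything in compound 3 except one group: bromo in place of ethyl on an aromatic carbon. In short, 3-ethylphenyl becomes 3-bromophenyl.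

Among the measured compounds shown here, no measured step makes this exact exchange, so the evidence is indirect. Two steps end at compound 3. Putting 3-ethylphenyl in place of 2-ethylphenyl gives a 2.7-fold lower number from compound 1 to compound 3 (0.43 log units; beyond the scatter). Putting 3-ethylphenyl in place of 3,4-difluorophenyl gives a 4.8-fold lower number from compound 2 to compound 3 (0.68 log units; beyond the scatter). Both are modest, so changes on this ring have so far shifted the number only moderately. For the measured compounds named here, the only measured compound without an ethyl group, compound 2, stands at 620 nM, which hints that losing the ethyl may raise the number somewhat. Going by these compounds, that is a single compound, however, and bromo itself is untested here.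

A small move to a higher number is therefore expected, possibly no larger than the scatter. The expected step is a 1.5-fold higher number from compound 3 to compound 4 (0.19 log units; within the scatter). For compound 4 the estimated value is 200 nM, with an expected range of 80 nM to 500 nM.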

Compound 4, half-maximal inhibitory concentration: 100 nM
Compound 4: middle estimate off by 2.0-fold (0.30 log units), on the high side; low and high end bracket the measured number.
By their numbers in this assay, from the lowest: compounds 4 and 3 (each within the scatter of the next); then compounds 1 and 2 (each within the scatter of the next).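

In this assay, bromo and ethyl on this aromatic carbon, meta to a large group, cannot be told apart: the exchange gives a 1.3-fold lower number from compound 3 to compound 4 (0.11 log units; within the scatter), even though bromo is a single heavy atom and ethyl has two. The earlier advantage of 3-ethylphenyl therefore does not depend on ethyl itself, as 3-bromophenyl also stands clear of the other two rings, with a 6.2-fold lower number from compound 2 to compound 4 (0.79 log units; beyond the scatter) and a 3.5-fold lower number from compound 1 to compound 4 (0.54 log units; beyond the scatter); compound 2 goes against any broad rule about this place, as its 3,4-difluorophenyl ring also carries a group there without sharing the lower number. Nothing measured here explains why ethyl and bromo give such similar results.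

Going by these compounds, it remains open whether other groups on this carbon, such as methoxy, an amine or a carboxylic acid, would stay level with compound 3 and compound 4 or move the number clearly. A single chloro or a single fluoro there would also show whether the second fluoro of compound 2 matters, and whether the tolerance seen so far extends to other halogens.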